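This account rests on a few compounds, and the source may have more. Where it says the series, first, only, none or still open, it means among the compounds named here.

compound 1 `Cc1ccc(S(=O)(=O)N[C@@H](CC(=O)NC(C)(C)C)C(=O)NCCNC(=O)c2cc(C)ccc2F)cc1`: > 11000 nM
compound 2 `Cc1ccc(S(=O)(=O)N[C@@H](CC(=O)NC(C)(C)C)C(=O)NCCNC(=O)Nc2ccccc2)cc1`: > 11000 nM
compound 3 `Cc1ccc(S(=O)(=O)N[C@@H](CC(=O)NC(C)(C)C)C(=O)NCCNC(=O)c2cc(C)ccn2)cc1`: > 11000 nM

In an ADME assay on HepG2 cells (Homo sapiens) for cytotoxicity (a lower number here means that less compound is needed, a higher number that more compound is needed for the effect), compound 1 gives > 11000 nM, which is a limit of the assay and not a number. Compound 2 likewise gives > 11000 nM, again a limit. Compound 3 gives > 11000 nM, also a limit. Compound 1 therefore stands at the limit of > 11000 nM in this assay, at which 3 of the 3 values shown sit, and the other two values shown sit there with it. The unmeasured compound 4 `Cc1ccc(S(=O)(=O)N[C@@H](CC(=O)NC(C)(C)C)C(=O)NCCNC(=O)c2cccc(C(F)(F)F)c2)cc1` differs from compound 1 by 3-(trifluoromethyl)phenyl in place of 2-fluoro-5-methylphenyl on a carbonyl carbon. The measured steps that alter the same carbonyl carbon are a step that the two limits leave unreadable from compound 1 to compound 2, a step that the two limits leave unreadable from compound 1 to compound 3 and a step that the two limits leave unreadable from compound 2 to compound 3; none of them has a readable size, as both ends of each pair sit at the limit. No direction or size can be drawn from them for the step to compound 4, and the expectation is that compound 4 will also sit at the limit. Compound 4 is estimated at 20000 nM, with a range from 8000 nM to 60000 nM. The expected step from compound 1 to compound 4 is a step that the limit leaves unreadable from compound 1 to compound 4.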

Compound 4, half-maximal effective concentration: > 11000 nM
Compound 4: only a limit was reported; the forecaster's own chance of this, stated with the estimate: 85%; the middle value does not contradict the limit.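

Going by these compounds alone, no step from compound 4 to compound 1, compound 2 or compound 3 can be read, since all four compounds share one limit: the limit of > 11000 nM in this assay, at which 4 of the 4 values shown sit. The compounds shown leave open how far apart they lie in this assay and whether any group on the carbonyl carbon would give a number rather than a limit.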